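From propargyl to (thiophen-3-yl)methyl on a shared core

A few compounds are considered here, and "the series" means these few. Any claim that something is new, unique, unknown or untested is made for them only; others in the source may bear on it.

Going by the values given here, in a functional assay on U-373MG ATCC cells for inhibition, with U373 MG (Homo sapiens) as the target, read by MTT assay, with a stated time of 7 days (a lower number here means a stronger inhibitor of growth, a higher number a weaker inhibitor of growth), compound 1 `C#CCn1nnc2c(C(N)=O)ncn2c1=O` gives 37600 nM, the only true number among the three compounds measured on this core. Compound 2 `NC(=O)c1ncn2c(=O)n(Cc3ccccc3)nnc12` reads > 50000 nM, which is a limit of the assay. Compound 3 `NC(=O)c1ncn2c(=O)n(Cc3cccs3)nnc12` reads > 50000 nM, likewise a limit. The picture therefore rests on (the limit of > 50000 nM in this assay, at which 2 of the 3 values shown sit).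

Compound 4 `NC(=O)c1ncn2c(=O)n(Cc3ccsc3)nnc12` differs from compound 1 by thiophen-3-yl in place of ethynyl on a saturated chain carbon bound to an aromatic nitrogen. Among the compounds with values here, two measured steps bear on this change. With phenyl there is an at least 1.3-fold higher number from compound 1 to compound 2 (0.12 log units; that floor lies within the scatter), and with thiophen-2-yl there is an at least 1.3-fold higher number from compound 1 to compound 3 (0.12 log units; that floor lies within the scatter). As far as these compounds go, both are floors, so their true size stays open, and a step that the two limits leave unreadable from compound 2 to compound 3 adds nothing further. A step toward a higher number in this assay is therefore expected, though not one that can be claimed beyond the scatter. The expected change is a 1.5-fold higher number from compound 1 to compound 4 (0.17 log units; within the scatter). For compound 4 the estimate is 55000 nM, with an expected range from 30000 nM to 100000 nM.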

Compound 4, concentration for 50% growth inhibition: > 50000 nM
Compound 4 ended at the assay's limit; the forecaster's own chance of this, stated with the estimate: 80%; the middle value lies beyond the limit too.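

In this assay, the change from propargyl to (thiophen-3-yl)methyl gives an at least 1.3-fold higher number from compound 1 to compound 4 (0.12 log units; that floor lies within the scatter), a floor that does not establish a real loss of growth inhibition. With compound 4, a third aromatic group on the saturated chain carbon bound to an aromatic nitrogen reaches the limit, so moving from thiophen-2-yl to thiophen-3-yl brings no readable number, and compound 1 still stands alone with a true value. The steps among compound 2, compound 3 and compound 4 cannot be read, because all three rest on the same limit: the limit of > 50000 nM in this assay, at which 3 of the 4 values shown sit.

As far as these compounds go, how far the true values of these three compounds lie from that limit stays open, as does the true size of their steps from compound 1. Also open, from the compounds shown here alone, is whether an amine, a carboxylic acid or a longer chain in this place would give a readable number.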